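From a Methyl to a Dimethylaminoethyl Arm on the Shared Core

A few compounds are considered here, and "the series" means these few. Any claim that something is new, unique, unknown or untested is made for them only; others in the source may bear on it.

Measured so far:
Compound 1, `CN(C)CCn1cnnc1-c1cc(Oc2ccc(NC(=O)N/N=C/c3ccccc3O[N+](=O)[O-])cc2F)ccn1`, gives 1270 nM.
Compound 2, `CN(C)CCn1cnnc1-c1cc(Oc2ccc(NC(=O)N/N=C/c3c(Cl)cccc3Cl)cc2F)ccn1`, gives 350 nM.
Compound 3, `Cn1cnnc1-c1cc(Oc2ccc(NC(=O)N/N=C/c3ccccc3)cc2F)ccn1`, gives 15700 nM.

These three compounds were tested in a functional assay on NCI-H460 cells (Homo sapiens) for cytotoxicity, read by MTT assay, with a stated time of 72 h; on this read-out lower numbers stand for stronger inhibition and higher numbers for weaker inhibition. Compound 3 stands highest of the three numbers, weakest on this read-out: compound 1 sits far below it, and compound 2 sits further below still. Within the data shown here, the one measured step, a 3.6-fold lower number from compound 1 to compound 2 (0.56 log units; beyond the scatter), concerns only the phenyl group and so does not bear directly on the change considered here.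

Compound 4, `CN(C)CCn1cnnc1-c1cc(Oc2ccc(NC(=O)N/N=C/c3ccccc3)cc2F)ccn1`, differs from compound 3 by (dimethylamino)methyl in place of hydrogen on a saturated chain carbon bound to an aromatic nitrogen. Among the measured compounds shown here, no measured pair isolates this change. What is known is that both compounds carrying the longer arm, compound 1 and compound 2, lie well under compound 3, though they also carry different phenyl groups. On that indirect basis a lower number is expected for compound 4, with wide uncertainty; the step is estimated as a 7.9-fold lower number from compound 3 to compound 4 (0.89 log units; beyond the scatter), giving an expected value for compound 4 of 2000 nM, in the range 500 nM to 8000 nM.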

Compound 4, half-maximal inhibitory concentration: 1780 nM
Beside the measured number, compound 4's estimate is 1.1-fold (0.05 log units) above it; low and high end bracket the measured number.
By their numbers in this assay, from the lowest: compound 2; then compounds 1 and 4 (each within the scatter of the next); then compound 3.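

In this assay, with the phenyl group held constant, exchanging methyl for 2-(dimethylamino)ethyl gives an 8.8-fold lower number from compound 3 to compound 4 (0.95 log units; beyond the scatter) and so provides a direct reading of this change at this position, free of any difference in the phenyl group. With the longer arm fixed, the phenyl groups can now also be compared on their own: the step of a 5.1-fold higher number from compound 2 to compound 4 (0.71 log units; beyond the scatter) favours 2,6-dichlorophenyl over plain phenyl, whereas a 1.4-fold higher number from compound 1 to compound 4 (0.15 log units; within the scatter) shows no readable difference between nitrooxy and hydrogen on an aromatic carbon.

On these data alone, it remains open whether a longer chain, a ring amine such as morpholine, or a carboxylic acid in place of the dimethylamino group would move the number further, and whether the arm gives a similar step with other phenyl groups. No evidence is available on what lies behind these steps.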